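The source may hold more compounds than are shown below. What is called first, only, known or untested is meant among the compounds shown, and "the series" means these compounds.

Compound 1 `CCCCCCC#Cc1cn(C/C=C/CN2C(=O)c3ccccc3C2=O)c(=O)[nH]c1=O` gives 43000 nM in a functional assay on L1210 cells (Mus musculus) for antiproliferative activity, read by MTT assay, with a stated time of 2 days; a higher number here means a weaker inhibitor, a lower number a stronger inhibitor.
Compound 2 `O=C1c2ccccc2C(=O)N1C/C=C\Cn1cc(C#Cc2ccc(Br)cc2)c(=O)[nH]c1=O` gives 448000 nM in this assay.
Compound 3 `O=C1c2ccccc2C(=O)N1C/C=C/Cn1cc(C#CCCc2ccccc2)c(=O)[nH]c1=O` gives 44000 nM in this assay.

Compound 1 and compound 3 sit together at the low end of these three numbers, within the usual scatter of each other, while compound 2 shows a clearly higher number in this assay and so the weaker inhibition. Compound 4 `CCCCCC#Cc1cn(C/C=C/CN2C(=O)c3ccccc3C2=O)c(=O)[nH]c1=O` has not yet been measured. It differs from compound 1 by hydrogen in place of methyl on a saturated chain carbon, five bonds along the chain from a triple-bonded carbon, a shortening of the chain at its far end.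

Among the measured compounds shown here, the one measured step that touches the same region of the molecule is a 1.0-fold higher number from compound 1 to compound 3 (0.01 log units; within the scatter), where a much larger change at the chain end left the number essentially unchanged. For the measured compounds named here, nothing among the measured compounds tells how shortening the chain by one carbon acts, but the tolerance seen in compound 3 suggests no step beyond the scatter in this assay.

Compound 4 is therefore expected to give about 50000 nM, with a likely range from 20000 nM to 120000 nM, which means an expected step of a 1.2-fold higher number from compound 1 to compound 4 (0.07 log units; within the scatter).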

Compound 4, half-maximal inhibitory concentration: > 500000 nM
Compound 4: a limit, no number (the forecaster's own chance of this, stated with the estimate: 5%); middle value at least 10-fold (1.00 log units) away from the limit.
By their numbers in this assay, from the lowest: compounds 1 and 3 (each within the scatter of the next); then compound 2. At a limit, above all of these: compound 4.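

For compound 4 the reading in this assay is a limit of the assay and not a number: the limit of > 500000 nM in this assay, at which 1 of the 4 values shown sits.

Even so, the limit is enough to show an at least 11-fold higher number from compound 1 to compound 4 (1.06 log units; beyond the scatter), so hydrogen in place of methyl at this place, five bonds along the chain from a triple-bonded carbon, matters far more than the earlier pair suggested. The other comparison gives an at least 11-fold higher number from compound 3 to compound 4 (1.05 log units; beyond the scatter): butyl and phenyl at this chain end give numbers within the scatter of each other, while propyl stands apart from both, so tolerance here does not simply follow the size of the change.

Going by these compounds, the true number for compound 4 stays unknown, and so does the full size of these steps. On these data alone, whether a longer chain, or a chain ending in an amine or a carboxylic acid, would keep the number of compound 1 also remains open.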